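This account rests on a few compounds, and the source may have more. Where it says the series, first, only, none or still open, it means among the compounds named here.

Values in an assay for inhibition of Nitric oxide synthase, inducible (Homo sapiens), read by scintillation counting, with a stated time of 30 min; on this read-out higher numbers stand for weaker inhibition and lower numbers for stronger inhibition:
compound 1 `CNC(=S)NCCC(O)c1ccccc1N` — 350000 nM
compound 2 `CCCNC(=S)NCCC(O)c1ccccc1N` — 880000 nM
compound 3 `CNC(=S)NCCC(O)c1cc(OC)ccc1N` — 130000 nM

Compound 2 gives the highest number of the three. Its nearest neighbour is compound 1; the step of a 2.5-fold higher number from compound 1 to compound 2 (0.40 log units; beyond the scatter) separates them, the only structural difference being ethyl in place of hydrogen on a saturated chain carbon bound to an amide-type nitrogen. Compound 3, which carries methoxy in place of hydrogen on an aromatic carbon of compound 1, sits furthest from compound 2 among the measured compounds.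

Compound 4 `CCCNC(=S)NCCC(O)c1cc(Cl)ccc1N` is not yet measured. Relative to compound 2 it shows (chloro in place of hydrogen on an aromatic carbon). Among the measured compounds shown here, no measured step introduces chloro anywhere, so the only step that bears on this change is a 2.7-fold lower number from compound 1 to compound 3 (0.43 log units; beyond the scatter), where a different group entered an aromatic carbon of the same ring. That step was modest and beyond the scatter, in the direction of a lower number. The group entering here is not the same one. The expected step is therefore of similar or smaller size, toward a lower number, with wide uncertainty.

For compound 4 in this assay the expected value is 450000 nM, in the range 150000 nM to 1300000 nM, corresponding to an expected step of a 2.0-fold lower number from compound 2 to compound 4 (0.29 log units; within the scatter).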

Compound 4, half-maximal inhibitory concentration: > 1000000 nM
Compound 4: only a limit was reported (the forecaster's own chance of this, stated with the estimate: 20%); at least 2.2-fold (0.34 log units) between middle value and limit.
By their numbers in this assay, from the lowest: compound 3; then compound 1; then compound 2. At a limit, above all of these: compound 4.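

In this assay compound 4 gives > 1000000 nM, which is a limit and not a number. At this aromatic carbon, para to an amino group, methoxy gave a 2.7-fold lower number from compound 1 to compound 3 (0.43 log units; beyond the scatter), whereas chloro gave an at least 1.1-fold higher number from compound 2 to compound 4 (0.05 log units; that floor lies within the scatter), so the lower number seen with methoxy does not carry over to chloro, although the two steps start from different compounds. Going by these compounds, only a floor can be given for the chloro step, and its true size stays unknown because the reading for compound 4 ends at a limit: the limit of > 1000000 nM in this assay, at which 1 of the 4 values shown sits.

The compounds shown do not separate the effect of the entering group from that of the chain on the thiourea-type nitrogen, since chloro appears only with the compound 2 chain and methoxy only with the compound 1 chain. On these data alone, how a fluoro, hydroxy or dimethylamino group would read at this same aromatic carbon also remains open, as does any reading for compound 4 beyond its limit.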